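This account rests on a few compounds, and the source may have more. Where it says the series, first, only, none or still open, it means among the compounds named here.

The study compares three measured compounds and one that is still to be measured. Compound 1 `CNc1nc(NCc2ccc(NC(=O)c3ccc(Cl)cc3)cc2)c2ccc(C)cc2n1` and compound 2 `CNc1nc(NCc2ccc(NC(=O)c3ccc(Cl)cc3)cc2)c2c(C)cccc2n1` are built from the same atoms joined differently; the difference between the two cores is not broken down here. In an in vitro ADME assay on microsomes from liver (Rattus norvegicus) for metabolic stability (a lower number here means that the compound disappears faster, a higher number that the compound lasts longer), compound 1 gives 0.3 h, and in this assay compound 2 gives 0.2 h, a pair of numbers that lie within the scatter of each other. Compound 3 `CNc1nc(NCc2ccc(NC(=O)c3ccc(Cl)nc3)cc2)c2c(C)cccc2n1` comes from compound 2 by the change (6-chloropyridin-3-yl in place of 4-chlorophenyl on a carbonyl carbon), and in this assay compound 3 gives 0.0333 h, which amounts to a 6.0-fold lower number from compound 2 to compound 3 (0.78 log units; beyond the scatter). Compound 4 `CNc1nc(NCc2ccc(NC(=O)c3ccc(Cl)nc3)cc2)c2ccc(C)cc2n1` comes from compound 1 by the change (6-chloropyridin-3-yl in place of 4-chlorophenyl on a carbonyl carbon); the place is the same in both cases, so this is the same kind of change, made twice among the compounds shown. From compound 1 to compound 4 the step in this assay is expected to be a 6.0-fold lower number from compound 1 to compound 4 (0.78 log units; beyond the scatter), set beside the earlier one, because the measured step of a 6.0-fold lower number from compound 2 to compound 3 (0.78 log units; beyond the scatter) shows what this change did on the other core. Compound 4 is therefore expected to give about 0.05 h, most likely between 0.02 h and 0.15 h.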

Compound 4, half-life in the Rattus norvegicus assay: 0.133 h
For compound 4 the middle estimate is 2.7-fold (0.42 log units) below the measured one, within the range that was stated.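

In the Rattus norvegicus assay the swap of 4-chlorophenyl for 6-chloropyridin-3-yl gave a 2.3-fold lower number from compound 1 to compound 4 (0.35 log units; beyond the scatter), so the direction carried over from one core to the other, but the size of the step did not: the same change on two cores in the Rattus norvegicus assay, a 6.0-fold lower number (0.78 log units; beyond the scatter) from compound 2 to compound 3 and a 2.3-fold lower number (0.35 log units; beyond the scatter) from compound 1 to compound 4, 2.7-fold (0.43 log units) apart, beyond the scatter of two such steps

This shows that, in this series, the step measured on one core gives the sign of the step on the other more safely than its size, yet two cores are too few to make a rule, and the numbers do not tell why the two steps differ. In a physicochemical assay for solubility, at pH 7.4 (on this read-out lower numbers stand for lower solubility and higher numbers for higher solubility), compound 1 gives 1 ug/mL and compound 4 gives 7 ug/mL. Solubility moved the other way on the core of compound 1, so there the change traded some stability for solubility: the measured solubility of compound 1, 1 ug/mL, and of compound 4, 7 ug/mL, a 7.0-fold higher number (0.85 log units; beyond the scatter)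

The compounds shown leave open whether that solubility step also appears on the core of compound 2. They also leave open how the two read-outs would respond if the chlorine of the 6-chloropyridin-3-yl group gave way to a fluorine or a methoxy group.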